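The source may hold more compounds than are shown below. What is called first, only, known or untested is meant among the compounds shown, and "the series" means these compounds.

Measured compounds in this series:

compound 1 `Cc1cc(C(=O)c2ccccc2)cc(C)c1OCC(=O)Nc1nc(-c2ccccc2)cs1`: 19400 nM
compound 2 `COc1ccc(-c2csc(NC(=O)COc3c(C)cc(C(=O)c4ccccc4)cc3C)n2)cc1`: 39400 nM
compound 3 `Cc1cc(C(=O)c2cccc(Br)c2)ccc1OCC(=O)Nc1nc(-c2ccccc2)cs1`: 23800 nM

All three were run in a functional assay on DLA cells (Mus musculus) for cytotoxicity, read by MTT assay, with a stated time of 48 h; a lower number here means a stronger inhibitor, a higher number a weaker inhibitor. Compound 1 and compound 2 share a core and differ in one place only: methoxy in place of hydrogen on an aromatic carbon. That change carried a measured step, a 2.0-fold higher number from compound 1 to compound 2 (0.31 log units; beyond the scatter), a modest shift toward a weaker inhibitor that lies beyond the usual scatter.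

Compound 3 carries a different core; the difference between the core of compound 3 and the core of compound 1 is not broken down here. Its value in this assay sits close to that of compound 1, within the scatter, and its gap to compound 2 is also within the scatter, so no order among the three can be claimed from these numbers alone.

Compound 4 `COc1ccc(-c2csc(NC(=O)COc3ccc(C(=O)c4cccc(Br)c4)cc3C)n2)cc1` has not yet been measured. It relates to compound 3 in the same way that compound 2 relates to compound 1: methoxy in place of hydrogen on an aromatic carbon. The place of the change reads the same word for word in both pairs, so this is the same change set on the other core. For the measured compounds named here, with only one prior instance of this change, the expectation for compound 4 is an estimated step of a 2.0-fold higher number from compound 3 to compound 4 (0.30 log units; within the scatter), resting on the step of a 2.0-fold higher number from compound 1 to compound 2 (0.31 log units; beyond the scatter) seen on the first core. On that basis compound 4 is expected to come in at about 47000 nM, with a likely range from 24000 nM to 95000 nM.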

Compound 4, half-maximal inhibitory concentration: 36600 nM
Beside the measured number, compound 4's estimate is 1.3-fold (0.11 log units) above it; the range from low to high includes it.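

On the core of compound 3, methoxy in place of hydrogen on an aromatic carbon gives, in this assay, a 1.5-fold higher number from compound 3 to compound 4 (0.19 log units; within the scatter), a step too small on its own to count as a real shift. Set beside the earlier step, the same change gives results on the two cores that cannot be told apart: the same change on two cores in this assay, a 2.0-fold higher number (0.31 log units; beyond the scatter) from compound 1 to compound 2 and a 1.5-fold higher number (0.19 log units; within the scatter) from compound 3 to compound 4, 1.3-fold (0.12 log units) apart, within the scatter of two such steps. So phenyl to 4-methoxyphenyl carries from one core to the other without a detectable difference in step size, and both steps have the same sign; but only the step on the first core lies beyond the scatter, so this does not establish a firm loss on the second core, and two pairs give no general rule for the series or any reason for the steps.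

The compounds shown leave open how the same place on the phenyl ring, para to a large group, would read with a different substituent such as fluoro, chloro, hydroxy, an amine or a carboxylic acid, or with a longer chain such as ethoxy in place of methoxy. They also leave open whether the step would hold on any core beyond these two, or in any assay other than this assay.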